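A few compounds are considered here, and "the series" means these few. Any claim that something is new, unique, unknown or untested is made for them only; others in the source may bear on it.

Measured so far in a functional assay on L1210 cells (Mus musculus) for cytotoxicity; a lower number here means a stronger inhibitor, a higher number a weaker inhibitor:

- compound 1, `Cc1ccc(NC(=O)/C=C/C(=O)N2C/C(=C\c3ccccc3)C(=O)/C(=C/c3ccccc3)C2)cc1`: 5800 nM
- compound 2, `O=C(/C=C/C(=O)N1C/C(=C\c2ccccc2)C(=O)/C(=C/c2ccccc2)C1)Nc1ccccc1`: 3600 nM

Compound 2 gives the lowest of the two numbers shown, but the step between the two is a 1.6-fold lower number from compound 1 to compound 2 (0.21 log units; within the scatter), so the two values cannot be placed in order; both sit in the low micromolar region of this assay.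

Compound 3, `O=C(/C=C/C(=O)N1C/C(=C\c2ccccc2)C(=O)/C(=C/c2ccccc2)C1)Nc1ccc(Cl)cc1`, is not yet measured. Compared with compound 2 the change is chloro in place of hydrogen on an aromatic carbon; read one bond further out, phenyl becomes 4-chlorophenyl, anilino becomes (4-chlorophenyl)amino, and the chloro sits para to a large group.

Among the measured compounds shown here, the only step bearing on this is the one from compound 1 to compound 2, where methyl at the same aromatic carbon was replaced by hydrogen: a 1.6-fold lower number from compound 1 to compound 2 (0.21 log units; within the scatter). A one-atom change at this position thus produced no step beyond the scatter. On that basis compound 3 is expected to stay close to compound 2, with a step of a 1.1-fold lower number from compound 2 to compound 3 (0.05 log units; within the scatter) in this assay, in no direction beyond the scatter. The estimate for compound 3 is 3200 nM, with a range from 1300 nM to 8000 nM.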

Compound 3, half-maximal inhibitory concentration: 7800 nM
The estimate for compound 3 lay 2.4-fold (0.39 log units) below the measured number; the measured number falls inside the stated range.
By their numbers in this assay, from the lowest: compounds 2, 1 and 3 (each within the scatter of the next, the first and the last beyond it).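

In this assay, this aromatic carbon, para to a large group, now gives a step beyond the scatter: a 2.2-fold higher number from compound 2 to compound 3 (0.34 log units; beyond the scatter). The step is modest, but it shows that the position is not indifferent to every one-atom change, which the methyl-to-hydrogen pair alone could not show. Chloro and methyl at this carbon cannot be told apart, with a 1.3-fold higher number from compound 1 to compound 3 (0.13 log units; within the scatter), and nothing measured alongside these numbers speaks to why chloro in place of hydrogen moves the value.

Whether any substituent at this carbon raises the number cannot be said from three compounds, since methyl goes against such a reading: a 1.6-fold lower number from compound 1 to compound 2 (0.21 log units; within the scatter) stays within the scatter, so only chloro separates from hydrogen. From the compounds shown here alone, it also remains open whether a methoxy, a nitro or a dimethylamino group on this carbon would side with chloro or stay with hydrogen, and whether chloro on another carbon of the same ring would give a step of similar size.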